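This account rests on a few compounds, and the source may have more. Where it says the series, first, only, none or still open, it means among the compounds named here.

Measured in a physicochemical assay for solubility, with a stated time of 18 h, at pH 7.4; a lower number here means a less soluble compound, a higher number a more soluble compound:
compound 1 `CN(C)c1cccc(Oc2ccc3c(NCCCNCc4ccco4)ccnc3c2)c1`: 14500 nM
compound 2 `c1ccc(Cc2ccc3c(NCCCNCc4ccco4)ccnc3c2)cc1`: 4200 nM
compound 3 `c1coc(CNCCCNc2ccnc3cc(CC4CCCCC4)ccc23)c1`: 4200 nM

Compound 3 stands level with compound 2 at the digits given, the pair together the lowest of the three numbers; compound 1 is the furthest, with a 3.5-fold lower number from compound 1 to compound 3 (0.54 log units; beyond the scatter).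

Compound 4 `COc1ccc(Oc2ccc3c(NCCCNCc4ccco4)ccnc3c2)cc1` is not yet measured. The change from compound 3 is 4-methoxyphenoxy in place of cyclohexylmethyl on an aromatic carbon. Among the measured compounds shown here, two measured steps bear on it. no change at the digits printed from compound 2 to compound 3 (within the scatter) shows no separation between the aromatic and the saturated six-membered ring on the chain. a 3.5-fold lower number from compound 1 to compound 3 (0.54 log units; beyond the scatter) is the reverse of an aryloxy-for-cyclohexylmethyl exchange, though compound 1 carried 3-(dimethylamino)phenoxy rather than 4-methoxyphenoxy. A rise in this assay is therefore expected for compound 4, probably smaller than the step from compound 1, estimated as a 1.7-fold higher number from compound 3 to compound 4 (0.22 log units; within the scatter), giving 7000 nM with a range of 2500 nM to 20000 nM.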

Compound 4, solubility: 14500 nM
For compound 4 the middle estimate is 2.1-fold (0.32 log units) below the measured one; the measured number falls inside the stated range.
By their numbers in this assay, from the lowest: compounds 2 and 3 (each within the scatter of the next); then compounds 1 and 4 (each within the scatter of the next).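

In this assay the 4-methoxyphenoxy group on this aromatic carbon stands apart from both carbon-linked groups, cyclohexylmethyl (a 3.5-fold higher number from compound 3 to compound 4 (0.54 log units; beyond the scatter)) and benzyl (a 3.5-fold higher number from compound 2 to compound 4 (0.54 log units; beyond the scatter)). Changing only the aryl group on the oxygen gives a different picture (no change at the digits printed from compound 1 to compound 4 (within the scatter)), so among the compounds shown, 4-methoxyphenyl and 3-(dimethylamino)phenyl read alike on that oxygen. No supporting data explain these readings.

Still open, from the compounds shown here alone, is whether unsubstituted phenoxy or cyclohexyloxy would match these two aryloxy compounds. Those groups would help separate the contribution of the oxygen link from that of the aromatic ring.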